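The source may hold more compounds than are shown below. What is called first, only, known or untested is meant among the compounds shown, and "the series" means these compounds.

Of the compounds shown here, three share one core and have been tested in an assay on isolated protein for inhibition of tyrosine-protein kinase receptor UFO (Homo sapiens), read by ELISA; on this read-out higher numbers stand for weaker inhibition and lower numbers for stronger inhibition. Compound 1 `Nc1ncnc2[nH]cc(-c3ccc(NC(=O)c4cn(CC5CCOCC5)cc(-c5ccc(F)cc5)c4=O)cc3)c12` gives 0.2 nM. Compound 2 `Cn1cc(-c2ccc(NC(=O)c3cn(CC4CCOCC4)cc(-c4ccc(F)cc4F)c3=O)cc2)c2c(N)ncnc21` gives 0.8 nM. Compound 3 `Cn1cc(C(=O)Nc2ccc(-c3cn(C)c4ncnc(N)c34)cc2)c(=O)c(-c2ccc(F)cc2)c1` gives 5 nM. On these numbers compound 2 stands in the middle: its number is higher than that of compound 1 and lower than that of compound 3, and both gaps lie beyond the usual scatter of this assay.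

Compound 4 `Cn1cc(-c2ccc(NC(=O)c3cn(CC4CCOCC4)cc(-c4ccccc4)c3=O)cc2)c2c(N)ncnc21` has not yet been measured. It differs from compound 2 in one place only: phenyl in place of 2,4-difluorophenyl on an aromatic carbon. The fluorine atoms of the 2,4-difluorophenyl group are thus absent in compound 4, while everything else, including the (oxan-4-yl)methyl group and the amide linkage to the shared core, stays the same. Within the data shown here, no pair among the measured compounds isolates this particular change, so there is no measured step to lean on. The expectation is a small move toward a higher number, at most on the edge of the scatter, giving a 1.9-fold higher number from compound 2 to compound 4 (0.27 log units; within the scatter). Compound 4 is therefore estimated at 1.5 nM, within a range from 0.5 nM to 5 nM.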

Compound 4, half-maximal inhibitory concentration: 1 nM
The estimate for compound 4 lay 1.5-fold (0.18 log units) above the measured number, within the range that was stated.
By their numbers in this assay, from the lowest: compound 1; then compounds 2 and 4 (each within the scatter of the next); then compound 3.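

In this assay, the step of a 1.3-fold higher number from compound 2 to compound 4 (0.10 log units; within the scatter) shows that the 2,4-difluorophenyl group and plain phenyl cannot be told apart at this position, on an aromatic carbon of a six-membered aromatic ring with 1 nitrogen. Among these compounds, this is the first pair to isolate a change at this position, since no two earlier compounds differed in one place only. Within the scatter of this assay, both fluorine atoms can therefore be absent without a measurable difference in this setting, and nothing measured here offers an explanation for that result.

As far as these compounds go, whether a methoxy group or an amine on this phenyl ring, or a methyl group in place of the whole ring, would read the same remains open. Also open, from the compounds shown here alone, is whether removing fluorine would read the same way in compound 1 or compound 3, which differ from compound 4 in more than one place.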